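Allyl in place of phenyl on the ring nitrogen: compound 4

The source may hold more compounds than are shown below. What is called first, only, known or untested is meant among the compounds shown, and "the series" means these compounds.

Measured so far in a functional assay on the whole organism (strain albino) for inhibition, with Rattus norvegicus as the target, read by paw edema, with a stated time of 5 h, at a dose of 0.28 mmol/kg by the oral route; a higher number here means more inhibition at the dose given (going by the name of the read-out), a lower number less inhibition:
- compound 1, `C=CCn1c(SCC(=O)c2ccccc2)nnc1-c1ccccc1`, gives 66%
- compound 2, `COc1ccc(-c2nnc(SC/C(=N/O)c3ccccc3)n2-c2ccccc2)cc1`, gives 73%
- compound 3, `O/N=C(/CSc1nnc(-c2ccccc2)n1-c1ccccc1)c1ccccc1`, gives 75%

Compound 2 stands within the usual scatter of both other measured compounds in this assay: its number and those of compound 1 and compound 3 cannot be ranked against one another. Within the data shown here, the only single-place step among them, a number 2 percentage points higher from compound 2 to compound 3 (within the scatter), concerns the methoxy group and is itself within the scatter.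

Compound 4, `C=CCn1c(SC/C(=N/O)c2ccccc2)nnc1-c1ccc(OC)cc1`, differs from compound 2 in one place: allyl in place of phenyl on an aromatic nitrogen. Among the measured compounds shown here, no measured step changes the group on the ring nitrogen alone. Compound 1 carries an allyl there but also differs from compound 2 at the side chain and at the methoxy, so only its two values can be compared, and compound 1 gives 66% against compound 2 with 73%, a gap within the scatter. Nothing here points to a step beyond the scatter, so the expected step is a number 3 percentage points lower from compound 2 to compound 4 (within the scatter). Compound 4 is therefore estimated at 70% in this assay, with a range from 58% to 80%.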

Compound 4, a percentage reported as inhibition, in the whole organism at one dose (the size of the read-out at that dose, not a potency): 57%
The estimate for compound 4 lay 13 percentage points above the measured number, and the stated range ends above it.
By their numbers in this assay, from the lowest: compounds 4, 1, 2 and 3 (each within the scatter of the next, the first and the last beyond it).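

In this assay, among these compounds, the ring nitrogen is the first place where a single change gives a step beyond the scatter, namely a number 16 percentage points lower from compound 2 to compound 4 (beyond the scatter), whereas the only earlier single-place step, a number 2 percentage points higher from compound 2 to compound 3 (within the scatter), stayed within it. Phenyl and allyl are therefore not interchangeable on this nitrogen, at least with the 4-methoxyphenyl group and the oxime side chain of compound 2 in place. No available measurement explains this step.

The step does not separate loss of the aromatic ring from the drop in heavy atoms or the presence of the double bond; a saturated propyl chain or a benzyl group on this nitrogen would address that. Going by these compounds, whether the step holds with hydrogen in place of methoxy also remains open.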